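The compounds below may be only part of what the source reports. "The series", "measured", "known", "first", "only" and "open" are said of these compounds alone.

Measured so far:
- Compound 1, `FC(F)(F)c1ccccc1OC1CCN(c2ccc(-c3nnco3)nn2)CC1`, in an assay on microsomes from liver for inhibition of acyl-CoA desaturase 1 (Rattus norvegicus) (a higher number here means a weaker inhibitor, a lower number a stronger inhibitor), gives 22 nM.
- Compound 2, `OCc1nnc(-c2ccc(N3CCC(Oc4ccccc4C(F)(F)F)CC3)nn2)o1`, in this assay gives 2.9 nM.

Compound 2 has the lowest number of the two, which in this assay means the stronger inhibitor; compound 1 sits at a number that is a 7.6-fold lower number from compound 1 to compound 2 (0.88 log units; beyond the scatter), so the gap between them is real.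

Compound 3, `O=C(NCCC1CC1)c1ccc(N2CCC(Oc3ccccc3C(F)(F)F)CC2)nn1`, is not yet measured. It keeps the whole shared core of compound 2 and changes only the group at one end: (2-cyclopropylethyl)carbamoyl in place of 5-(hydroxymethyl)-1,3,4-oxadiazol-2-yl on an aromatic carbon.

Within the data shown here, only one measured step gives any guidance, and it is indirect. That step, a 7.6-fold lower number from compound 1 to compound 2 (0.88 log units; beyond the scatter), shows how much the hydroxymethyl group on the five-membered ring was worth. Compound 3 loses that ring and the hydroxymethyl group together, and the group that enters is built quite differently. The direction and size of the effect of such a swap cannot be read from two compounds, so the expectation for compound 3 is a weakening back toward the level of compound 1, with wide uncertainty: the estimated step is a 6.9-fold higher number from compound 2 to compound 3 (0.84 log units; beyond the scatter). Compound 3 is therefore expected to give about 20 nM in this assay, within a range from 4 nM to 100 nM.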

Compound 3, half-maximal inhibitory concentration: 14 nM
Compound 3: the middle estimate sits 1.4-fold (0.15 log units) above what was measured; the range from low to high includes it.
By their numbers in this assay, from the lowest: compound 2; then compounds 3 and 1 (each within the scatter of the next).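

The position on the six-membered aromatic ring with 2 nitrogen, para to a large group, turns out not to depend on a five-membered aromatic ring in this assay: an open chain, (2-cyclopropylethyl)carbamoyl, in place of the plain 1,3,4-oxadiazol-2-yl gives a 1.6-fold lower number from compound 1 to compound 3 (0.20 log units; within the scatter) and so cannot be told apart from it, although the two groups share little beyond their place on the ring. The picture changes when the ring carries its hydroxymethyl group, since going to the same chain gives a 4.8-fold higher number from compound 2 to compound 3 (0.68 log units; beyond the scatter) and leaves compound 2 as the strongest inhibitor of the three, so this position tolerates quite different groups while the 5-(hydroxymethyl)-1,3,4-oxadiazol-2-yl group still has a real edge over the carbamoyl chain. No measurement here explains why these groups rank as they do.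

The compounds shown leave open whether a hydroxymethyl or other hydroxyl group at the end of the carbamoyl chain would bring the same gain it brought on the five-membered ring. They also leave open how much the cyclopropyl ring itself matters, which a plain butyl chain or a shorter ethyl chain on the carbamoyl nitrogen could test.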